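Working notes: from compound 2 to compound 3

The source may hold more compounds than are shown below. What is called first, only, known or untested is meant among the compounds shown, and "the series" means these compounds.

Compound 1 `C#CCNC(=O)c1cccc2c1cc(C)n2-c1nc2c(c(NCc3ccccc3)n1)CCCC2`: > 24 h (a limit)
Compound 2 `CC#CCNC(=O)c1cccc2c1cc(C)n2-c1nc2c(c(NCc3ccccc3)n1)CCCC2`: > 24 h (a limit)
Compound 3 `C#CC(=O)Nc1cccc2c1cc(C)n2-c1nc2c(c(NCc3ccccc3)n1)CCCC2`: not yet measured

The read-out here is a physicochemical assay for pharmacokinetics, read by LC-MS, in phosphate buffer, tested at 1 uM; a lower number here means that the compound disappears faster, a higher number that the compound lasts longer. Compound 2 gives > 24 h, which is a limit and not a number. Compound 1 gives > 24 h, which is also a limit. Within the data shown here, the whole series so far comes down to the limit of > 24 h in this assay, at which 2 of the 2 values shown sit, so compound 2 has no exact position.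

The change to compound 3 is a group of 5 heavy atoms (3 carbon, 1 nitrogen, 1 oxygen; no ring) in place of a group of 7 heavy atoms (5 carbon, 1 nitrogen, 1 oxygen; no ring), on an aromatic carbon. The entering group is (ethynylcarbonyl)amino, on an aromatic carbon of a six-membered aromatic ring of carbon only.

Among the measured compounds shown here, the only measured step is a step that the two limits leave unreadable from compound 1 to compound 2. It concerns a different change, methyl in place of hydrogen on a triple-bonded carbon, and offers no size to carry over. No step beyond the scatter is therefore expected in this assay, although the uncertainty lies mainly towards a shorter half-life. The expected step is a step that the limit leaves unreadable from compound 2 to compound 3. A result reported only as a limit is quite possible.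

For compound 3 the estimate is 30 h, with an expected range from 12 h to 72 h.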

Compound 3, half-life: 0.21 h
Compound 3: the middle estimate sits 140-fold (2.15 log units) above what was measured; the whole stated range lies above it.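

In this assay, this aromatic carbon proves sensitive to what it carries: (ethynylcarbonyl)amino in place of propargylcarbamoyl gives an at least 110-fold lower number from compound 1 to compound 3 (2.05 log units; beyond the scatter), and the matching change from the group of compound 2 gives an at least 110-fold lower number from compound 2 to compound 3 (2.05 log units; beyond the scatter). A triple bond alone does not go with the short half-life, since compound 1 and compound 2 carry one too; leaving and entering groups also match in their counts of donors, acceptors, double bonds and triple bonds, while the entering group has its nitrogen on the aromatic carbon and its carbonyl directly on the triple bond. The earlier values of compound 1 and compound 2 are both limits, so the step between them cannot be read and both new steps are bounds rather than exact sizes: the limit of > 24 h in this assay, at which 2 of the 3 values shown sit.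

The compounds shown do not separate the effect of the nitrogen on the aromatic carbon from that of the carbonyl on the triple bond. A propanoylamino group at this place, with no triple bond, or a but-2-ynoylamino group, with a methyl on the triple bond, would bear directly on that question.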